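Ethyl to 4-Methoxycyclohexyl on an Amide Nitrogen

This account rests on a few compounds, and the source may have more. Where it says the series, first, only, none or still open, it means among the compounds named here.

Measured compounds:
compound 1 `CNC(=O)c1cc(C(=O)N[C@H]2[C@@H]3C[C@@H](O)C[C@@H]32)n([C@@H](C)c2cccc(Cl)c2)n1` gives 197 nm/s
compound 2 `CNC(=O)c1cc(C(=O)N[C@H]2CC[C@H](OC)CC2)c([C@@H](C)c2ccccc2)o1` gives 303 nm/s
compound 3 `CCNC(=O)c1cc(C(=O)NC)nn1[C@@H](C)c1ccccc1` gives 435 nm/s

In an ADME assay for permeability (on this read-out lower numbers stand for lower permeability and higher numbers for higher permeability), compound 3 has the highest of the three numbers. Its gap to compound 2 lies within the scatter, so the two cannot be told apart; its gap to compound 1 lies beyond the scatter. Compound 4 `CNC(=O)c1cc(C(=O)N[C@H]2CC[C@H](OC)CC2)n([C@@H](C)c2ccccc2)n1` has not yet been measured. It differs from compound 3 in one place: 4-methoxycyclohexyl in place of ethyl on an amide-type nitrogen. Compound 2 carries the same (4-methoxycyclohexyl)amino group and gives 303 nm/s, which sits close to compound 3. The step from compound 3 to compound 4 is therefore expected to be small, a 1.5-fold lower number from compound 3 to compound 4 (0.16 log units; within the scatter), most likely within the scatter. For compound 4 a value of 300 nm/s is estimated, with a range from 150 nm/s to 600 nm/s.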

Compound 4, apparent permeability: 360 nm/s
Beside the measured number, compound 4's estimate is 1.2-fold (0.08 log units) below it; low and high end bracket the measured number.
By their numbers in this assay, from the lowest: compounds 1, 2, 4 and 3 (each within the scatter of the next, the first and the last beyond it).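

In this assay the change from ethyl to 4-methoxycyclohexyl on the amide-type nitrogen reads as a 1.2-fold lower number from compound 3 to compound 4 (0.08 log units; within the scatter) and so the far larger group, with its six-membered ring and its oxygen, leaves no difference that can be told from scatter. Among the compounds shown here, the earlier compounds offered no pair differing in one place, so this is the first direct reading of this position. Nothing at hand explains why the number holds. Going by these compounds, whether the same holds with an amine or a carboxylic acid in place of the methoxy group remains open, as does the effect of the same change on the core of compound 2.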